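Prenyl ether to fluorophenyl carbamate on the shared core

The source may hold more compounds than are shown below. What is called first, only, known or untested is meant among the compounds shown, and "the series" means these compounds.

Measured compounds:
compound 1 `CC(C)=CCOc1cc(=O)n(CCCO)c2c1CC(CC=C(C)C)C(C)(C)C2`, 7.5%
compound 2 `CC(C)=CCC1Cc2c(OC(=O)Nc3cccc(F)c3)cc(=O)n(CCCO)c2CC1(C)C`, 0%
compound 3 `CC(C)=CCC/C(C)=C/CC1Cc2c(OCC=C(C)C)cc(=O)n(CCCO)c2CC1(C)C`, 15.9%

In a functional assay on PANC-1 cells (Homo sapiens) for inhibition, read by MTT assay, with a stated time of 24 h, tested at 10 uM (on this read-out higher numbers stand for more inhibition at the one concentration tested (going by the name of the read-out) and lower numbers for less inhibition), compound 3 gives the highest of the three numbers, but compound 1 sits within the scatter of it, and only compound 2 lies beyond the scatter below it. Compound 4 `CC(C)=CCC/C(C)=C/CC1Cc2c(OC(=O)Nc3ccc(F)cc3)cc(=O)n(CCCO)c2CC1(C)C` is not yet measured; it differs from compound 3 in one place: (4-fluorophenyl)carbamoyl in place of 3-methylbut-2-en-1-yl on an oxygen on an aromatic ring.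

The step that bears on this change is a number 7.5 percentage points lower from compound 1 to compound 2 (within the scatter), in which the same oxygen carried a fluorinated phenylcarbamoyl group in place of the 3-methylbut-2-en-1-yl group; the number fell to nil, yet the fall stayed within the scatter. On this assay a comparable step is therefore estimated as a number 7.9 percentage points lower from compound 3 to compound 4 (within the scatter). Compound 4 is expected to give about 8%, with a range from 0% to 20%.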

Compound 4, a percentage reported as inhibition, at one concentration (the size of the read-out at that concentration, not a potency): 6.2%
The estimate for compound 4 lay 1.8 percentage points above the measured number, within the range that was stated.
By their numbers in this assay, from the lowest: compounds 2, 4, 1 and 3 (each within the scatter of the next, the first and the last beyond it).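

In this assay (4-fluorophenyl)carbamoyl in place of 3-methylbut-2-en-1-yl on the oxygen on the aromatic ring gives a number 9.7 percentage points lower from compound 3 to compound 4 (within the scatter) on the compound 3 background, so a step within the scatter is now seen with the added 3-methylbut-2-en-1-yl chain present and with fluorine in the 4-fluorophenyl arrangement. Nothing available explains this step.

Open, on these data alone, is whether a carbamoyl group carrying an amine or a carboxylic acid in place of the fluorine would move the number beyond the scatter. A single concentration also leaves potency open.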